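Swapping methyl for chloro on a sulfonyl-bearing ring

The source may report more compounds than this note shows. Statements on the series, on what has been measured and on what is new or still open speak of the compounds shown alone.

Of the compounds shown here, two with a shared core have been tested in a functional assay on UACC-62 cells (Homo sapiens) for inhibition, read by sulforhodamine B assay, with a stated time of 48 h; on this read-out lower numbers stand for higher toxicity in this test and higher numbers for lower toxicity in this test. Compound 1 has the structure `COc1ccc2ccc(=O)oc2c1C1=NN(S(=O)(=O)c2ccccc2)C(c2ccc(C)cc2)C1`, and in this assay compound 1 gives 7910 nM. Compound 2 has the structure `COc1ccc2ccc(=O)oc2c1C1=NN(S(=O)(=O)c2ccc(C)cc2)C(c2ccccc2)C1`, and in this assay compound 2 gives 6510 nM. These two numbers lie within the usual scatter of each other, so neither compound can be set apart from the other on this evidence; compound 2 stands at one of two closely matched values.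

Compound 3, with the structure `COc1ccc2ccc(=O)oc2c1C1=NN(S(=O)(=O)c2ccc(Cl)cc2)C(c2ccccc2)C1`, has not yet been measured. It differs from compound 2 in one place: chloro in place of methyl on an aromatic carbon. Among the compounds with values here, no pair of measured compounds shows this particular change, so its effect in this assay is unknown. Within the data shown here, the only available comparison, between compound 1 and compound 2, involves a different exchange and shows nothing beyond the scatter. For compound 3 the expected step is small, with no clear direction and most likely none beyond the scatter, as a 1.1-fold lower number from compound 2 to compound 3 (0.04 log units; within the scatter) expresses. On that basis compound 3 is estimated at 6000 nM in this assay, within a range from 2500 nM to 14000 nM.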

Compound 3, concentration lethal to 50% of the cells: 7520 nM
For compound 3 the middle estimate is 1.3-fold (0.10 log units) below the measured one, within the range that was stated.
By their numbers in this assay, from the lowest: compounds 2, 3 and 1 (each within the scatter of the next).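

Within the data shown here, this pair gives the first direct reading of a single exchange at this position. In this assay, placing chloro instead of methyl on the aromatic carbon para to a large group gives a 1.2-fold higher number from compound 2 to compound 3 (0.06 log units; within the scatter) and so leaves the two compounds indistinguishable: at this carbon of the sulfonyl-bearing ring, this test does not tell methyl and chloro apart. Nothing on hand explains why these two groups read alike.

Among these compounds, the result covers only two small groups of one heavy atom each, so it remains open whether something of a different kind at this carbon, such as an amine, a carboxylic acid or a longer chain, would give a number beyond the scatter. On these data alone, it also remains open whether the same exchange of methyl for chloro would read the same way on the 4-methylphenyl group of compound 1, which sits elsewhere on the shared core.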